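The source may hold more compounds than are shown below. What is called first, only, known or untested is meant among the compounds shown, and "the series" means these compounds.

Measured compounds and their values in an assay on HEK293 cells for activation of Kir3.1/Kir3.2 (Homo sapiens), read by thallium flux; on this read-out higher numbers stand for an effect only at larger amounts of compound and lower numbers for an effect already at smaller amounts:

Compound 1, `Cc1cc(NC(=O)Cn2nnc(-c3cc(Cl)cc(Cl)c3)n2)n(C2CCCCC2)n1`: 980 nM
Compound 2, `Cc1cc(NC(=O)Cn2nnc(-c3ccc(F)cc3)n2)n(C2CCCCC2)n1`: 180 nM
Compound 3, `Cc1cc(NC(=O)Cn2nnc(-c3ccnc(F)c3)n2)n(C2CCCCC2)n1`: 441 nM

Compound 3 holds the second highest of the three numbers in this assay ; it stands nearer to compound 1, with a 2.2-fold lower number from compound 1 to compound 3 (0.35 log units; beyond the scatter), than to compound 2, with a 2.5-fold higher number from compound 2 to compound 3 (0.39 log units; beyond the scatter). Compound 4, `Cc1cccc(-c2nnn(CC(=O)Nc3cc(C)nn3C3CCCCC3)n2)c1`, is not yet measured. It differs from compound 3 in one place: 3-methylphenyl in place of 2-fluoropyridin-4-yl on an aromatic carbon.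

Among the compounds with values here, two measured steps bear on this change. The aromatic ring of carbon only in place of the ring with one nitrogen is seen in the step from compound 3 back to compound 2, a 2.5-fold higher number from compound 2 to compound 3 (0.39 log units; beyond the scatter) read in reverse, a modest drop in number. Changing the substituents on the phenyl ring is seen in a 5.4-fold lower number from compound 1 to compound 2 (0.74 log units; beyond the scatter), also modest. Within the data shown here, no measured compound carries a methyl on that ring, so its own contribution is unknown. A modest step toward a lower number is therefore expected for compound 4, a 1.8-fold lower number from compound 3 to compound 4 (0.25 log units; within the scatter). The estimate for compound 4 in this assay is 250 nM, within a range from 100 nM to 700 nM.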

Compound 4, half-maximal effective concentration: 129 nM
Compound 4: middle estimate off by 1.9-fold (0.29 log units), on the high side; the range from low to high includes it.
By their numbers in this assay, from the lowest: compounds 4 and 2 (each within the scatter of the next); then compound 3; then compound 1.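

In this assay, within the data shown here, the 3-methylphenyl group gives a 3.4-fold lower number from compound 3 to compound 4 (0.53 log units; beyond the scatter) and a 7.6-fold lower number from compound 1 to compound 4 (0.88 log units; beyond the scatter), which shows that a methyl on a ring of carbon only is tolerated at this position on the five-membered aromatic ring, a point no earlier compound could address. Set against the 4-fluorophenyl group, the same group gives a 1.4-fold lower number from compound 2 to compound 4 (0.14 log units; within the scatter), which lies within the scatter, so this read-out does not tell these two rings apart. Nothing available here explains these steps.

Still open, going by these compounds, is how much of the result belongs to the methyl itself, which a plain phenyl ring would help to show. Also open, on these data alone, is how this position responds to a methoxy or trifluoromethyl group on the ring, or to an amine attached to it.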